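A few compounds are considered here, and "the series" means these few. Any claim that something is new, unique, unknown or untested is made for them only; others in the source may bear on it.

Measured compounds in an assay on isolated protein for inhibition of Apoptosis regulator Bcl-2 (Homo sapiens), read by fluorescence polarization; a higher number here means a weaker inhibitor, a lower number a stronger inhibitor:
compound 1, `Cc1cccc(N2C(=O)/C(=C/c3ccc(OCc4ccc(C(=O)O)cc4)cc3)SC2=S)c1`, gives > 10000 nM, which is a limit of the assay, not a number.
compound 2, `Cc1ccc(N2C(=O)/C(=C/c3ccc(OCc4ccc(C(=O)O)cc4)cc3)SC2=S)cc1`, gives > 10000 nM, also only a limit.
compound 3, `O=C(O)c1ccc(COc2ccc(/C=C3\SC(=S)N(c4ccc(Cl)cc4)C3=O)cc2)cc1`, gives > 10000 nM, again only a limit.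

Compound 3 therefore stands nowhere distinguishable from the other two: all three values sit at the limit of > 10000 nM in this assay, at which 3 of the 3 values shown sit, and no ranking among them can be read. The steps leading to compound 3 show this directly: a step that the two limits leave unreadable from compound 1 to compound 3 and a step that the two limits leave unreadable from compound 2 to compound 3, as does a step that the two limits leave unreadable from compound 1 to compound 2 between the other pair.

Compound 4, `O=C(O)c1ccc(COc2ccc(/C=C3\SC(=S)N(Cc4ccc(F)cc4)C3=O)cc2)cc1`, is the next candidate for this assay. It differs from compound 3 by 4-fluorobenzyl in place of 4-chlorophenyl on an amide-type nitrogen in a ring. Going by the values given here, none of the measured steps gives a readable size, so no direction or magnitude can be drawn from them for this change, and no measured evidence ties any property to the 4-fluorobenzyl or 4-chlorophenyl group.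

With every comparison so far ending at the limit, compound 4 is expected to stay near that limit as well, estimated at 15000 nM, with a range from 3000 nM to 60000 nM. The step that the limit leaves unreadable from compound 3 to compound 4 that this estimate implies is an expectation of essentially no readable change, not a measurement.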

Compound 4, inhibition constant: > 10000 nM
Compound 4 gave a limit, no number; the forecaster's own chance of this, stated with the estimate: 80%; the middle value is on the limit's open side.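

In this assay compound 4 gives > 10000 nM, again only a limit. Its steps from compound 1, compound 2 and compound 3 cannot be read, so the four compounds cannot be ranked: the limit of > 10000 nM in this assay, at which 4 of the 4 values shown sit. The compounds shown leave open whether any group on the amide-type nitrogen in the ring gives a measurable value.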